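Swapping Fluoro for Cyclohexyl: What the Data Allow

The source may hold more compounds than are shown below. What is called first, only, known or untested is meant among the compounds shown, and "the series" means these compounds.

Measured so far:
compound 1, `Fc1ccc2ncc(-c3nn[nH]n3)cc2c1`: < 25 mg/kg
compound 2, `Fc1cc(F)c2ncc(-c3nn[nH]n3)cc2c1`: 10 mg/kg

Both compounds were tested in a functional assay on the whole organism (strain Sprague-Dawley) for inhibition, with Rattus norvegicus as the target; on this read-out higher numbers stand for an effect only at larger amounts of compound and lower numbers for an effect already at smaller amounts. For compound 1 the result of < 25 mg/kg is a limit of the assay rather than a number. Compound 2 gives 10 mg/kg. For the measured compounds named here, the only measured step, fluoro in place of hydrogen on an aromatic carbon, is a step that the limit leaves unreadable from compound 1 to compound 2, and its size stays hidden by the limit of < 25 mg/kg in this assay, at which 1 of the 2 values shown sits. Compound 3, `c1nc2ccc(C3CCCCC3)cc2cc1-c1nn[nH]n1`, is not yet measured; it differs from compound 1 by cyclohexyl in place of fluoro on an aromatic carbon. Going by the values given here, no measured step exchanges one group for another of this kind, so none bears directly on this change, and there is no basis to expect a step in either direction beyond the scatter. Compound 3 is therefore expected to give 15 mg/kg, within 3 mg/kg to 60 mg/kg. The step from compound 1 to compound 3 is expected to be a step that the limit leaves unreadable from compound 1 to compound 3.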

Compound 3, minimum effective dose: 5 mg/kg
Compound 3: the middle estimate sits 3.0-fold (0.48 log units) above what was measured; low and high end bracket the measured number.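

The step from compound 1 to compound 3 cannot be read, because the value for compound 1 is a limit of the assay and not a number: the limit of < 25 mg/kg in this assay, at which 1 of the 3 values shown sits.

The compounds shown leave open whether cyclohexyl in place of fluoro changes the dose needed for an effect, and by how much.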